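From 4-Methoxyphenyl to 3-Bromophenyl on an Amide Nitrogen

The source may hold more compounds than are shown below. What is called first, only, known or untested is meant among the compounds shown, and "the series" means these compounds.

Compound 1 `CN(C)C(=O)c1cc2cnc(Nc3ccc(N)cn3)nc2n1C1CCCC1` gives 61.1%
Compound 2 `CN(C)C(=O)c1cc2cnc(Nc3ccc(NC(=O)C4(C(=O)Nc5cccc(O)c5)CC4)cc3)nc2n1C1CCCC1` gives 83.7%
Compound 3 `COc1ccc(NC(=O)C2(C(=O)Nc3ccc(Nc4ncc5cc(C(=O)N(C)C)n(C6CCCC6)c5n4)cc3)CC2)cc1` gives 96.1%
Compound 4 `CN(C)C(=O)c1cc2cnc(Nc3ccc(NC(=O)C4(C(=O)Nc5cccc(Br)c5)CC4)cc3)nc2n1C1CCCC1` is not yet measured

Within the data shown here, in a functional assay on T47D cells (Homo sapiens) for inhibition, read by CCK-8 assay, with a stated time of 72 h, tested at 10 uM (a higher number here means more inhibition of growth at the concentration tested, a lower number less inhibition of growth), compound 3 gives 96.1% as the highest of the three numbers so far, and its gaps to compound 1 and compound 2 lie beyond the usual scatter. Compound 4 has 3-bromophenyl in place of 4-methoxyphenyl on an amide-type nitrogen, and 3-bromophenyl in place of 4-methoxyphenyl on an amide-type nitrogen is the counted difference. One measured step changes a group at this same place: a number 12.4 percentage points higher from compound 2 to compound 3 (beyond the scatter), which was modest and came with 4-methoxyphenyl replacing 3-hydroxyphenyl. Among the measured compounds shown here, no measured compound carries bromine, so that step is only a rough guide to size. Compound 2, the closest measured neighbour, gives 83.7% with its 3-hydroxyphenyl, so a modest fall seems more likely than a rise. The expected change is a number 8.1 percentage points lower from compound 3 to compound 4 (within the scatter) in this assay as a modest fall. For compound 4 the estimated value is 88% with an expected range from 74% to 98%.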

Compound 4, percent growth inhibition at one concentration: 94.6%
Compound 4: middle estimate off by 6.6 percentage points, on the low side; the range from low to high includes it.
By their numbers in this assay, from the lowest: compound 1; then compound 2; then compounds 4 and 3 (each within the scatter of the next).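

In this assay, 3-bromophenyl can take the place of 4-methoxyphenyl on this amide-type nitrogen with a number 1.5 percentage points lower from compound 3 to compound 4 (within the scatter), so the high growth inhibition is kept with two quite different aryl groups. Bromo in place of hydroxy on the aromatic carbon gives a number 10.9 percentage points higher from compound 2 to compound 4 (beyond the scatter), and among these three compounds the 3-hydroxyphenyl of compound 2 goes with the lowest number. Nothing measured here gives a reason for these differences.

Going by these compounds, it remains open whether the number holds with an amine or a carboxylic acid on this phenyl ring, or with a cyclohexyl ring in its place. Also open, on these data alone, is whether compound 3 and compound 4 would separate at lower concentrations than the single one tested.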